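The compounds below may be only part of what the source reports. "The series", "measured", "known", "first", "only" and "open" are said of these compounds alone.

Compound 2 `CCCCNc1nc(N)c2nc(O)n(Cc3ccccc3)c2n1` is tested in a functional assay (spleen, spleen) for activation, with Mus musculus as the target (a higher number here means that more compound is needed for the effect, a lower number that less compound is needed), where compound 2 gives 1 uM. Compound 1 `Cc1nc(N)c2nc(O)n(Cc3ccccc3)c2n1` gives 1 uM in this assay, and the step of no change at the digits printed from compound 1 to compound 2 (within the scatter) shows that placing butylamino in place of methyl on an aromatic carbon left the number where it was. Compound 3 `CCCCCOc1nc(N)c2nc(O)n(Cc3ccccc3)c2n1` differs from compound 2 by pentyloxy in place of butylamino on an aromatic carbon. Among the compounds with values here, that single measured step, which was flat, is the only guide here, so the expected step is no change at the digits printed from compound 2 to compound 3 (within the scatter), within the scatter. Compound 3 is therefore expected to give 1 uM, in a range from 0.3 uM to 3 uM.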

Compound 3, minimum effective concentration: 0.01 uM
Compound 3: middle estimate off by 100-fold (2.00 log units), on the high side; the measured number lies below the stated range.
By their numbers in this assay, from the lowest: compound 3; then compounds 1 and 2 (each within the scatter of the next).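

Pentyloxy at this aromatic carbon between two ring nitrogen atoms changes the picture set by the earlier flat step: in this assay it gives a 100-fold lower number from compound 2 to compound 3 (2.00 log units; beyond the scatter) when it replaces butylamino, and a 100-fold lower number from compound 1 to compound 3 (2.00 log units; beyond the scatter) when it replaces methyl. The position is therefore sensitive to which group it carries, and far less compound is needed with pentyloxy there. No measurement at hand gives a reason for this. The step from butylamino to pentyloxy alters the linking atom and the chain together, so the compounds shown leave open which of the two matters. A butoxy or pentylamino group would separate them, and a longer alkoxy chain would show whether the trend continues.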